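The compounds below may be only part of what the source reports. "The series", "measured", "known", "first", "only" and "open" are said of these compounds alone.

In a functional assay on DLD-1 cells (Homo sapiens) for antiproliferative activity, read by CellTiter-Glo, with a stated time of 72 h (on this read-out lower numbers stand for stronger inhibition and higher numbers for weaker inhibition), compound 1 `Cc1noc(C)c1S(=O)(=O)N1CCC(N2CCC(C)CC2)CC1` gives only a limit, > 5000 nM. Compound 2 `CC1CCN(C2CCN(S(=O)(=O)c3cccc(Cl)c3)CC2)CC1` likewise gives only a limit, > 5000 nM. The step that the two limits leave unreadable from compound 1 to compound 2 therefore has no readable size, since both values sit at the limit of > 5000 nM in this assay, at which 2 of the 2 values shown sit. Compound 3 `CC1CCN(C2CCN(S(=O)(=O)c3ccc(Cl)cc3Cl)CC2)CC1` differs from compound 2 by 2,4-dichlorophenyl in place of 3-chlorophenyl on a sulfonyl sulfur. For the measured compounds named here, no measured step bears readably on this change, and nothing beyond the scatter is expected from it. The estimated step that the limit leaves unreadable from compound 2 to compound 3 is expected to be small. Compound 3 is expected to stay at the limit, with an estimate of 7000 nM in this assay, between 2500 nM and 20000 nM.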

Compound 3, half-maximal inhibitory concentration: 1 nM
Compound 3: the middle estimate sits 7000-fold (3.85 log units) above what was measured; the measured number lies below the stated range.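

In this assay, the group on the sulfonyl sulfur can decide activity: 2,4-dichlorophenyl in place of 3-chlorophenyl gives an at least 5000-fold lower number from compound 2 to compound 3 (3.69 log units; beyond the scatter), and 2,4-dichlorophenyl in place of 3,5-dimethyl-1,2-oxazol-4-yl gives an at least 5000-fold lower number from compound 1 to compound 3 (3.69 log units; beyond the scatter). Both sizes are bounds, as each step starts from a limit. Compound 3 alone stands clear of the limit shared by the other compounds: the limit of > 5000 nM in this assay, at which 2 of the 3 values shown sit.

Open, on these data alone, is whether 2-chlorophenyl or 4-chlorophenyl alone would carry the step. Also open, as far as these compounds go, is whether 2,4-difluorophenyl or 2,4-dimethylphenyl would keep it.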